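Amino for Chloro on a Second Benzyl Core

The source may report more compounds than this note shows. Statements on the series, on what has been measured and on what is new or still open speak of the compounds shown alone.

Measured so far:
Compound 1 `ClCc1ccccc1Cn1cnc2c(Cl)nc(Cl)nc21`: 5240 nM
Compound 2 `ClCc1cccc(Cn2cnc3c(Cl)nc(Cl)nc32)c1`: 6450 nM
Compound 3 `Nc1nc(Cl)c2ncn(Cc3ccccc3CCl)c2n1`: 8510 nM

In a functional assay on UACC-62 cells (Homo sapiens) for cytotoxicity, read by sulforhodamine B assay, with a stated time of 48 h (a higher number here means that more compound is tolerated, a lower number that less compound is tolerated), compound 1 gives 5240 nM and compound 3 gives 8510 nM. Compound 3 differs from compound 1 by one change, (amino in place of chloro on an aromatic carbon), and the step is a 1.6-fold higher number from compound 1 to compound 3 (0.21 log units; within the scatter). Compound 2 has the same atoms as compound 1 joined differently; the difference between the two cores is not broken down here. In this assay compound 2 gives 6450 nM, which lies within the scatter of compound 1 and of compound 3.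

Compound 4 `Nc1nc(Cl)c2ncn(Cc3cccc(CCl)c3)c2n1` is not yet measured. Going by the values given here, it arises from compound 2 by amino in place of chloro on an aromatic carbon, the same change, at the same kind of place, as the one from compound 1 to compound 3. Among the compounds with values here, on the single precedent the expectation for this assay is a step of about a 1.6-fold higher number from compound 2 to compound 4 (0.19 log units; within the scatter), resting on a 1.6-fold higher number from compound 1 to compound 3 (0.21 log units; within the scatter), which stayed within the scatter. Compound 4 is therefore estimated at 10000 nM, with a range from 5000 nM to 21000 nM.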

Compound 4, concentration lethal to 50% of the cells: 13500 nM
Beside the measured number, compound 4's estimate is 1.4-fold (0.13 log units) below it; the measured number falls inside the stated range.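

In this assay, going by these compounds alone, amino in place of chloro on an aromatic carbon gives a 2.1-fold higher number from compound 2 to compound 4 (0.32 log units; beyond the scatter), and this can be set beside the same change on the other core: the same change on two cores in this assay, a 1.6-fold higher number (0.21 log units; within the scatter) from compound 1 to compound 3 and a 2.1-fold higher number (0.32 log units; beyond the scatter) from compound 2 to compound 4, 1.3-fold (0.11 log units) apart, within the scatter of two such steps The two steps cannot be told apart, so between these two cores the change carries over with no detectable difference in size, although only the step on the core of compound 2 passes beyond the scatter, and only modestly. This rests on just two pairs of compounds in one assay, so it gives no general rule for other cores and does not explain why the number moves.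

The compounds shown leave open what a methoxy group or a dimethylamino group would do on that same aromatic carbon, where only chloro and amino appear here. They also leave open how much the chloromethyl group contributes, which a hydroxymethyl group in its stead could help to test.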